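An Isomeric Amide Side Chain After Compound 2

A few compounds are considered here, and "the series" means these few. Any claim that something is new, unique, unknown or untested is made for them only; others in the source may bear on it.

In a functional assay on HepG2 cells (Homo sapiens) for antiproliferative activity, read by MTT assay, with a stated time of 48 h (a lower number here means a stronger inhibitor, a higher number a weaker inhibitor), compound 1 `CCn1c(C(=O)N(C)CC(=O)O)ccc1C(CC)(CC)c1ccc(OCCC(O)(CC)CC)c(C)c1` gives 5710 nM and compound 2 `CCn1c(C(=O)N(C)CCO)ccc1C(CC)(CC)c1ccc(OCCC(O)(CC)CC)c(C)c1` gives 510 nM as the lower of the two numbers. Compound 3 `CCn1c(C(=O)NC(C)CO)ccc1C(CC)(CC)c1ccc(OCCC(O)(CC)CC)c(C)c1` keeps the shared core and has not yet been measured. The change is (1-(hydroxymethyl)ethyl)amino in place of (2-hydroxyethyl)(methyl)amino on a carbonyl carbon and it sits on a carbonyl carbon, with the same atoms joined differently. Among the compounds with values here, only one measured step bears on it. That large step, an 11-fold lower number from compound 1 to compound 2 (1.05 log units; beyond the scatter) with hydroxymethyl in place of carboxy on a saturated chain carbon bound to an amide-type nitrogen, involves a different exchange. No carboxy group enters or leaves here, so compound 2 at 510 nM is the better guide. The expected step is a 1.3-fold higher number from compound 2 to compound 3 (0.11 log units; within the scatter) and nothing beyond the scatter is expected. In this assay the expected value for compound 3 is 650 nM with an estimated range of 220 nM to 1900 nM around it.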

Compound 3, half-maximal inhibitory concentration: 43100 nM
Beside the measured number, compound 3's estimate is 66-fold (1.82 log units) below it; the measured number lies above the stated range.
By their numbers in this assay, from the lowest: compound 2; then compound 1; then compound 3.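

In this assay, the side chain on the carbonyl carbon proves far from interchangeable: with the same atoms joined differently, (1-(hydroxymethyl)ethyl)amino in place of (2-hydroxyethyl)(methyl)amino gives an 85-fold higher number from compound 2 to compound 3 (1.93 log units; beyond the scatter) and shows that this position responds to the arrangement of these atoms, not only to their identity. The isomeric hydroxyl-bearing chain also ranks behind the carboxy-bearing one, with a 7.5-fold higher number from compound 1 to compound 3 (0.88 log units; beyond the scatter) in the same assay, so a hydroxyl group in this side chain does not by itself give the lower number seen for compound 2. No measurement available here explains this loss.

The change removes the methyl from the amide nitrogen and adds a branch on the chain at once, and the compounds shown cannot separate these two features. An unbranched (2-hydroxyethyl)amino group or a branched chain that keeps the methyl on the amide nitrogen would bear on that question.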